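This account rests on a few compounds, and the source may have more. Where it says the series, first, only, none or still open, it means among the compounds named here.

In an ADME assay on microsomes (Homo sapiens) for metabolic stability (on this read-out lower numbers stand for slow clearance and higher numbers for fast clearance), compound 1 (`CNC(=O)[C@@H]1CCCN1S(=O)(=O)c1ccc(Cl)c(COc2cccc3c(C(F)(F)F)cc(C)nc23)c1Cl`) gives 250 mL/min/kg, compound 2 (`Cc1cc(C(F)(F)F)c2cccc(OCc3c(Cl)ccc(S(=O)(=O)N4CCC[C@H]4C(N)=O)c3Cl)c2n1`) gives 167 mL/min/kg and compound 3 (`COC[C@@H]1CCCN1S(=O)(=O)c1ccc(Cl)c(COc2cccc3c(C(F)(F)F)cc(C)nc23)c1Cl`) gives 450 mL/min/kg. Compound 3 thus sits with compound 1 at the upper end of these numbers: a 1.8-fold higher number from compound 1 to compound 3 (0.26 log units; within the scatter) stays within the scatter, while a 2.7-fold higher number from compound 2 to compound 3 (0.43 log units; beyond the scatter) is a modest step beyond it. a 1.5-fold lower number from compound 1 to compound 2 (0.18 log units; within the scatter) also stays within the scatter.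

Next is compound 4 (`Cc1cc(C(F)(F)F)c2cccc(OCc3c(Cl)ccc(S(=O)(=O)N4CC[C@@H](N(C)C)C4)c3Cl)c2n1`), which carries 3-(dimethylamino)pyrrolidin-1-yl in place of 2-(methoxymethyl)pyrrolidin-1-yl on a sulfonyl sulfur. The measured steps all stay within the group carried by a saturated ring carbon, whereas this change replaces the whole group on the sulfonyl sulfur, so none of them transfers directly. They offer only the range they span. In this assay, no step beyond the scatter is therefore expected, and the estimated move is a 1.6-fold lower number from compound 3 to compound 4 (0.21 log units; within the scatter). For compound 4 the expected value is 280 mL/min/kg, with an estimated range of 130 mL/min/kg to 560 mL/min/kg.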

Compound 4, clearance: 167 mL/min/kg
The estimate for compound 4 lay 1.7-fold (0.22 log units) above the measured number, within the range that was stated.
By their numbers in this assay, from the lowest: compounds 2, 4, 1 and 3 (each within the scatter of the next, the first and the last beyond it).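

On the sulfonyl sulfur, 3-(dimethylamino)pyrrolidin-1-yl in place of 2-(methoxymethyl)pyrrolidin-1-yl gives in this assay a 2.7-fold lower number from compound 3 to compound 4 (0.43 log units; beyond the scatter), which shows that the whole group at this place can be replaced and the number still stays inside the range already seen. Against the two carbamoyl-bearing groups the new group shows no separation, with no change at the digits printed from compound 2 to compound 4 (within the scatter) and a 1.5-fold lower number from compound 1 to compound 4 (0.18 log units; within the scatter), so a dimethylamino group on the ring serves here as well as a carbamoyl or methylcarbamoyl group. No measured evidence on the origin of these numbers is available for this series.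

The step changes both the group and its ring carbon, so the contribution of each stays unresolved. A 3-(methoxymethyl)pyrrolidin-1-yl group, a primary amine or a carboxylic acid on the pyrrolidine would help separate the two, as would the opposite stereocentre of compound 4.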